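Pyrrolidine carbamate ether to piperidine ether on the shared core

The compounds below may be only part of what the source reports. "The series", "measured", "known", "first", "only" and "open" are said of these compounds alone.

Measured compounds:
compound 1 `Cc1ccc(NC(=O)c2cccc(C(F)(F)F)c2)cc1N1Cc2cnc(O[C@H]3CCN(C(=O)OC(C)(C)C)C3)nc2N(C)C1=O` gives 30 nM
compound 2 `Cc1ccc(Nc2ncc3c(n2)N(C)C(=O)N(c2cc(NC(=O)c4cccc(-c5ccccc5)c4)ccc2C)C3)cc1N` gives 23 nM
compound 3 `Cc1cccc(C(=O)Nc2ccc(C)c(N3Cc4cnc(Nc5ccc(C)c(N)c5)nc4N(C)C3=O)c2)c1` gives 68.8 nM

In a functional assay on K562 cells (Homo sapiens) for antiproliferative activity, read by CellTiter-Glo and CCK-8 assay, with a stated time of 72 h (on this read-out lower numbers stand for stronger inhibition of growth and higher numbers for weaker inhibition of growth), compound 1 gives 30 nM, the second highest of the three numbers; compound 2 sits within the scatter of compound 1, while compound 3 lies beyond it on the higher side. For the measured compounds named here, the only step measured between compounds that differ in one place is a 3.0-fold higher number from compound 2 to compound 3 (0.48 log units; beyond the scatter), a change on the amide aryl part of the shared core, not on the ether substituent.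

Compound 4 `Cc1ccc(NC(=O)c2cccc(C(F)(F)F)c2)cc1N1Cc2cnc(OC3CCNCC3)nc2N(C)C1=O` differs from compound 1 by piperidin-4-yl in place of 1-(tert-butoxycarbonyl)pyrrolidin-3-yl on an oxygen on an aromatic ring. Going by the values given here, no measured step touches this position, so nothing indicates the direction or size of the step, and the estimate rests on compound 1 alone with a widened range. The expected step is a 1.2-fold higher number from compound 1 to compound 4 (0.07 log units; within the scatter), none beyond the scatter. Compound 4 is therefore estimated at 35 nM, with a range from 10 nM to 120 nM.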

Compound 4, concentration for 50% growth inhibition: 220 nM
Compound 4: middle estimate off by 6.3-fold (0.80 log units), on the low side; measured number outside the range, above it.
By their numbers in this assay, from the lowest: compounds 2 and 1 (each within the scatter of the next); then compound 3; then compound 4.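

In this assay, for the compounds shown here, the substituent on the ether oxygen proves to be a position that responds, with a 7.3-fold higher number from compound 1 to compound 4 (0.87 log units; beyond the scatter) on going to piperidin-4-yl from 1-(tert-butoxycarbonyl)pyrrolidin-3-yl; the only earlier step lay on the amide aryl part. The change is a bundle: 12 heavy atoms leave and 6 enter, the five-membered ring becomes six-membered, the carbonyl-bearing carbamate and the defined stereocentre go, and a hydrogen-bond donor appears. Nothing available on this change offers an explanation for the result.

Going by these compounds alone, the single step cannot assign the loss to any one of these differences. On these data alone, a 1-(tert-butoxycarbonyl)piperidin-4-yl group and a free pyrrolidin-3-yl group on the same oxygen would separate the effect of the ring from that of the carbamate, and the opposite stereocentre remains open as well.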